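A few compounds are considered here, and "the series" means these few. Any claim that something is new, unique, unknown or untested is made for them only; others in the source may bear on it.

Compound 1 `Cc1ccnc(/C(N)=N/NC(=S)N2CCSCC2)c1` and compound 2 `Cc1ccnc(/C(N)=N/NC(=S)N2CCCCC2)c1` share one core and differ only in the ring on the thiocarbonyl carbon. In a functional assay on MCF7 cells (Homo sapiens) for cytotoxicity, read by MTT assay, with a stated time of 72 h, tested at 3 uM (on this read-out higher numbers stand for more inhibition of growth at the one concentration tested and lower numbers for less inhibition of growth), compound 1 gives 33.8%, and compound 2 gives 29.4%; the step of a number 4.4 percentage points lower from compound 1 to compound 2 (within the scatter) lies within the scatter. On these two numbers compound 2 stands lowest, but its gap to compound 1 is not a real difference. Compound 3 `Cc1ccnc(/C(N)=N/NC(=S)N2CCCC2)c1` carries the next change at the same place: pyrrolidin-1-yl in place of piperidin-1-yl on a thiocarbonyl carbon. Within the data shown here, the only measured step on that position, from compound 1 to compound 2, was within the scatter, so for compound 3 no step beyond the scatter is expected in this assay, in either direction, and the estimated step is a number 0.4 percentage points lower from compound 2 to compound 3 (within the scatter). Compound 3 is therefore expected near 29%, within 17% to 41%.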

Compound 3, percent growth inhibition at one concentration: 57.7%
Beside the measured number, compound 3's estimate is 28.7 percentage points below it; measured number outside the range, above it.
By their numbers in this assay, from the lowest: compounds 2 and 1 (each within the scatter of the next); then compound 3.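

In this assay, the ring on the thiocarbonyl carbon proves able to shift growth inhibition: pyrrolidin-1-yl brings a number 28.3 percentage points higher from compound 2 to compound 3 (beyond the scatter) and a number 23.9 percentage points higher from compound 1 to compound 3 (beyond the scatter). The position therefore responds to a ring change, although thiomorpholin-4-yl and piperidin-1-yl did not separate. Among these three compounds, only pyrrolidin-1-yl stands apart. As far as these compounds go, whether azetidin-1-yl, morpholin-4-yl or an open-chain diethylamino group would match compound 3 remains open. Nothing at hand bears on the cause of this step.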